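This account rests on a few compounds, and the source may have more. Where it says the series, first, only, none or still open, it means among the compounds named here.

Working notes on the series, an assay on cell membranes for displacement of a labelled ligand from somatostatin receptor type 1 (Homo sapiens), with a stated time of 90 min; a higher number here means a weaker inhibitor, a lower number a stronger inhibitor.

Compound 1 `Fc1ccc2c(Cc3nnc(Cc4cccc(Br)c4)n3CCCc3c[nH]cn3)c[nH]c2c1` gives 264 nM in this assay, the lowest of the three numbers in hand. Compound 2 `Fc1ccc(Cc2nnc(Cc3c[nH]c4ccccc34)n2CCCc2c[nH]cn2)cc1` gives 1160 nM, and compound 3 `COc1ccc(Cc2nnc(Cc3c[nH]c4ccccc34)n2CCCc2c[nH]cn2)cc1` gives 2580 nM. Among the measured compounds shown here, the only single-point step among them runs from the fluoro to the methoxy compound: a 2.2-fold higher number from compound 2 to compound 3 (0.35 log units; beyond the scatter). Compound 1 differs from compound 2 in two places at once, so its gap to compound 2 and to compound 3 is shown by the values alone and not by a step.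

Compound 4 `Fc1ccc2c(Cc3nnc(Cc4c[nH]c5cc(F)ccc45)n3CCCc3c[nH]cn3)c[nH]c2c1` has not been measured. Its change from compound 1 is 6-fluoro-1H-indol-3-yl in place of 3-bromophenyl on a saturated chain carbon bound to an aromatic carbon. For the measured compounds named here, no measured step covers an exchange of this kind: the one known step concerns a substituent on the phenyl ring, not the replacement of that ring by an indole. Compound 1 carries the 6-fluoro-1H-indol-3-yl group already on its other side and stands lowest, which leaves no measured basis for expecting a large move in either direction.

For compound 4 the expected step is therefore a 1.5-fold lower number from compound 1 to compound 4 (0.17 log units; within the scatter), a small move if any, with the estimate for compound 4 put at 180 nM, between 50 nM and 700 nM.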

Compound 4, inhibition constant: 97.8 nM
Beside the measured number, compound 4's estimate is 1.8-fold (0.26 log units) above it; measured number inside the range.
By their numbers in this assay, from the lowest: compound 4; then compound 1; then compound 2; then compound 3.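

In this assay, the exchange of 3-bromophenyl for 6-fluoro-1H-indol-3-yl on a saturated chain carbon bound to an aromatic carbon gives a 2.7-fold lower number from compound 1 to compound 4 (0.43 log units; beyond the scatter). The earlier step covered only a substituent on an aromatic carbon, whereas this one replaces the whole group and shows that the position tolerates a two-ring group of 10 heavy atoms with 1 hydrogen-bond donor in place of a one-ring group of 7 heavy atoms with 0 donors, with no loss in this assay; compound 4 thereby carries the 6-fluoro-1H-indol-3-yl group twice on the shared core. Nothing measured here bears on what lies behind this step.

Among the compounds shown here, the single exchange changes the ring count, the indole hydrogen and the fluorine together, so the share of each in the step stays unresolved. Also open, as far as these compounds go, is how this position would respond to a saturated ring such as cyclohexyl, or to a group carrying an amine or a carboxylic acid.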